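Aryl change on the core: compound 3 to compound 4

The source may hold more compounds than are shown below. What is called first, only, known or untested is meant among the compounds shown, and "the series" means these compounds.

The shared core differs across the series only in the aryl group attached to it. Compound 1 `CN1CCN(CCNCc2cn(-c3ccc(F)cc3F)nc2Cc2ccccc2)CC1` in an ADME assay on Huh-7 cells (Homo sapiens) for cytotoxicity (a higher number here means that more compound is tolerated, a lower number that less compound is tolerated), reaches only the limit > 20000 nM, a limit rather than a number. Compound 2 `CN1CCN(CCNCc2cn(-c3ccc(F)cc3F)nc2-c2ccc(OC(F)(F)F)cc2)CC1` gives 18000 nM in this assay. Compound 3 `Cc1ccccc1-c1nn(-c2ccc(F)cc2F)cc1CNCCN1CCN(C)CC1` stops at the limit > 20000 nM in this assay, which is where compound 3 stands, as the limit of > 20000 nM in this assay, at which 2 of the 3 values shown sit, records. The step of an at least 1.1-fold lower number from compound 1 to compound 2 (0.04 log units; that floor lies within the scatter) and the step of an at least 1.1-fold higher number from compound 2 to compound 3 (0.04 log units; that floor lies within the scatter) both lie within the scatter, while a step that the two limits leave unreadable from compound 1 to compound 3. Compound 4 `CN1CCN(CCNCc2cn(-c3ccc(F)cc3F)nc2-c2cccc(Cl)c2)CC1` changes compound 3 by 3-chlorophenyl in place of 2-methylphenyl on an aromatic carbon. Nothing measured separates these aryl groups beyond the scatter, so no step beyond it is expected: the estimate for compound 4 is 20000 nM (range 10000 nM to 40000 nM), an expected step of a number no higher from compound 3 to compound 4 (the limit leaves the size open).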

Compound 4, half-maximal cytotoxic concentration: 15000 nM
Compound 4: middle estimate off by 1.3-fold (0.12 log units), on the high side; the range from low to high includes it.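

In this assay, 3-chlorophenyl at this position gives a measured number rather than a limit, and all three of its steps stay within the scatter: an at least 1.3-fold lower number from compound 3 to compound 4 (0.12 log units; that floor lies within the scatter), a 1.2-fold lower number from compound 2 to compound 4 (0.08 log units; within the scatter) and an at least 1.3-fold lower number from compound 1 to compound 4 (0.12 log units; that floor lies within the scatter). The steps from compound 1 and from compound 3 are only floors, since each of those compounds is held as a limit: the limit of > 20000 nM in this assay, at which 2 of the 4 values shown sit.

From the compounds shown here alone, whether an amine or a carboxylic acid in place of the aryl group would move the number beyond the scatter stays open. So does the effect of a longer chain at this position.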